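Working notes: hydroxyethyl to hydroxyethoxy on the ring nitrogen

The source may hold more compounds than are shown below. What is called first, only, known or untested is meant among the compounds shown, and "the series" means these compounds.

Measured so far:
- compound 1 `CC(=O)OCCOn1cnc2c(S)nc(F)nc21`; in a functional assay on HeLa cells (Homo sapiens) for inhibition (a lower number here means a stronger inhibitor, a higher number a weaker inhibitor), compound 1 gives > 500000 nM, a limit of the assay and not a number.
- compound 2 `CC(O)n1cnc2c(S)nc(F)nc21`; in this assay compound 2 gives > 500000 nM, likewise a limit and not a number.

Compound 2 therefore stands nowhere on a scale of numbers: its value in this assay is a limit only, and the same holds for the other value shown, so that the limit of > 500000 nM in this assay, at which 2 of the 2 values shown sit, is the whole of the evidence on the series. Among the compounds with values here, no step between measured compounds can be taken from it.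

The next compound, compound 3 `OCCOn1cnc2c(S)nc(F)nc21`, differs from compound 2 in one place: 2-hydroxyethoxy in place of 1-hydroxyethyl on an aromatic nitrogen. Both hydroxyalkyl groups sit on the same aromatic nitrogen of the shared core of compound 2.

Within the data shown here, with two limits and no measured step, the size of the step in this assay cannot be read from the data, and the expectation is that compound 3 remains at the limit, with no step beyond the scatter. The step from compound 2 to compound 3 that this expectation means is a step that the limit leaves unreadable from compound 2 to compound 3. Compound 3 is expected to give about 600000 nM in this assay, with a range from 100000 nM to 3000000 nM.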

Compound 3, half-maximal inhibitory concentration: > 500000 nM
Compound 3 ended at the assay's limit; the forecaster's own chance of this, stated with the estimate: 85%; the middle value lies beyond the limit too.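

No new step can be read: compound 3 joins compound 1 and compound 2 at the limit, so the steps from compound 2 and from compound 1 to compound 3 cannot be read, and the series offers only this: the limit of > 500000 nM in this assay, at which 3 of the 3 values shown sit.

The compounds shown leave open how the groups on the aromatic nitrogen of the shared core rank, as none yields a number.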